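The source may hold more compounds than are shown below. What is called first, only, known or untested is meant among the compounds shown, and "the series" means these compounds.

Among the measured compounds shown here, in an assay on mitochondria from L6 cells (Rattus norvegicus) for activation, with a stated time of 90 min (on this read-out lower numbers stand for an effect already at smaller amounts and higher numbers for an effect only at larger amounts of compound), compound 2 `Oc1nc2nonc2nc1Nc1ccccc1` gives 66700 nM, the highest of the two numbers measured so far. For the measured compounds named here, its only neighbour, compound 1 `Oc1nc2nonc2nc1Nc1ccccc1F`, gives 12500 nM in this assay, and the step of a 5.3-fold higher number from compound 1 to compound 2 (0.73 log units; beyond the scatter) consists of hydrogen in place of fluoro on an aromatic carbon. Compound 3 `Oc1nc2nonc2nc1Nc1ccccc1OC(F)(F)F` differs from compound 2 by trifluoromethoxy in place of hydrogen on an aromatic carbon. That single measured step is the one that bears on the change: read in reverse, it shows that occupying this position on the aromatic ring, rather than leaving hydrogen there, brought a lower number beyond the scatter. Trifluoromethoxy now enters the same place, so a lowering of at least comparable size is expected, though with wide uncertainty, since no other step constrains it. Compound 3 is therefore estimated to give 10000 nM in this assay, between 3000 nM and 40000 nM, which means an expected step of a 6.7-fold lower number from compound 2 to compound 3 (0.82 log units; beyond the scatter).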

Compound 3, half-maximal effective concentration: 7100 nM
Beside the measured number, compound 3's estimate is 1.4-fold (0.15 log units) above it; the range from low to high includes it.
By their numbers in this assay, from the lowest: compounds 3 and 1 (each within the scatter of the next); then compound 2.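

The step of a 9.4-fold lower number from compound 2 to compound 3 (0.97 log units; beyond the scatter) in this assay shows that the lowering seen at this place on the aromatic ring is not confined to fluoro: trifluoromethoxy, with its 5 heavy atoms, also gives a lower number than hydrogen, beyond the scatter. The step of a 1.8-fold lower number from compound 1 to compound 3 (0.25 log units; within the scatter) lies within the scatter, so exchanging fluoro for trifluoromethoxy gives no readable difference. The position therefore accepts both groups, and the main readable contrast in this set is between either of them and hydrogen. Nothing available explains this result. Still open, as far as these compounds go, is how methyl, methoxy, an amine or a carboxylic acid at this place would compare with fluoro and trifluoromethoxy. The three compounds also share one core, so they leave open whether the same steps would hold on a different one.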